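A Shorter Arm on the Sulfur-Linked Chain

The source may hold more compounds than are shown below. What is called first, only, known or untested is meant among the compounds shown, and "the series" means these compounds.

Compound 2 `Cc1cc(-n2cccc2)c2ncc(CSCCc3ccccc3)n2c1` and compound 1 `Cc1cc(-c2ccsc2)c2ncc(CSCc3ccccc3)n2c1` have both been examined in an ADME assay on HEL cells (Homo sapiens) for cytotoxicity, with a stated time of 3 days; a higher number here means that more compound is tolerated, a lower number that less compound is tolerated. Compound 2 gives 100 ug/mL, and compound 1 gives 100 ug/mL; the two stand level within the usual scatter. Compound 3 `Cc1cc(-n2cccc2)c2ncc(CSCc3ccccc3)n2c1` has not yet been measured. It differs from compound 2 by phenyl in place of benzyl on a saturated chain carbon bound to a sulfur. Among the compounds with values here, no measured pair shows this kind of change, so no step beyond the scatter is expected no change at the digits printed from compound 2 to compound 3 (within the scatter). Compound 3 is therefore estimated to give about 100 ug/mL, with a range from 50 ug/mL to 200 ug/mL.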

Compound 3, minimum cytotoxic concentration: 100 ug/mL
Beside the measured number, compound 3's estimate shows no gap at the digits printed; the range from low to high includes it.
By their numbers in this assay, from the lowest: compounds 1, 2 and 3 (each within the scatter of the next).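

Phenyl in place of benzyl on a saturated chain carbon bound to a sulfur, which also reads as phenethyl to benzyl, gives no change at the digits printed from compound 2 to compound 3 (within the scatter) in this assay. 1H-pyrrol-1-yl in place of thiophen-3-yl on an aromatic carbon gives no change at the digits printed from compound 1 to compound 3 (within the scatter). Each of these two places now has a measured step, and neither step lies beyond the scatter.

Going by these compounds, whether an amine or a carboxylic acid in place of the benzyl, or a longer chain than phenethyl, would move this reading remains open. Nothing at hand offers an explanation for these level readings.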